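A hydroxyl joins the amide, a bromine leaves

The source may report more compounds than this note shows. Statements on the series, on what has been measured and on what is new or still open speak of the compounds shown alone.

Compound 1 `O=C(Nc1ccc(Sc2nc3ccccc3s2)c(Cl)c1)c1cc(Br)cc(Br)c1` stands only at a limit in an assay on isolated protein for inhibition of thiosulfate sulfurtransferase (Homo sapiens), with a stated time of 60 min, in the absence of a further agent; on this read-out higher numbers stand for weaker inhibition and lower numbers for stronger inhibition: compound 1 gives > 100000 nM, which is a limit of the assay and not a number. Compound 2 `O=C(Nc1cccc(Cl)c1)c1cc(Br)cc(Br)c1` likewise gives > 100000 nM, again a limit. Compound 3 `O=C(Nc1ccc(Sc2nc3ccccc3s2)cc1)c1cc(Br)cc(Br)c1` gives > 100000 nM, also a limit. The step that the two limits leave unreadable from compound 1 to compound 3 is therefore unreadable, and the limit of > 100000 nM in this assay, at which 3 of the 3 values shown sit, is all that the three values show. Compound 4 `O=C(Nc1ccc(Sc2nc3ccccc3s2)c(Cl)c1)c1cccc(Br)c1O` differs from compound 1 by 3-bromo-2-hydroxyphenyl in place of 3,5-dibromophenyl on a carbonyl carbon. Within the data shown here, no measured step resembles this change, and the three limits give no direction, so no size of step can be drawn from them. Compound 4 is expected to give an estimated 60000 nM, between 5000 nM and 300000 nM, a step of an at least 1.6-fold lower number from compound 1 to compound 4 (0.22 log units; that floor lies within the scatter) that is expected but rests on no measured neighbour.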

Compound 4, half-maximal inhibitory concentration: > 100000 nM
Compound 4: no number, only a limit (the forecaster's own chance of this, stated with the estimate: 60%); middle value at least 1.6-fold (0.22 log units) away from the limit.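

Among these compounds, compound 1 and compound 4 both stand only at a limit, so no step between them can be read: the limit of > 100000 nM in this assay, at which 4 of the 4 values shown sit.

In this assay the compounds shown leave open whether any change to the core of compound 1 gives a readable number.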